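The source may report more compounds than this note shows. Statements on the series, on what has been measured and on what is new or still open speak of the compounds shown alone.

Two ureas on the shared core have been measured in an assay on membranes from Cerebral cortex (strain Sprague-Dawley) for displacement of a labelled ligand from Translocator protein (Rattus norvegicus), read by radiometric assay; on this read-out lower numbers stand for stronger inhibition and higher numbers for weaker inhibition. Compound 1 `O=C(Nc1cccc(Cl)c1)Nc1cc2ncncc2cc1OCc1ccccc1Cl` gives 2790 nM in this assay. Compound 2 `O=C(Nc1ccc(Cl)c(Cl)c1)Nc1cc2ncncc2cc1OCc1cccc(F)c1` gives 1320 nM in this assay, the lower of the two numbers, and its gap to compound 1 lies beyond the usual scatter. The two differ in more than one place, so nothing can be read from them about any single change.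

Compound 3 `O=C(Nc1cc2ncncc2cc1OCc1cccc(F)c1)Nc1cccc2ccccc12` carries naphthalen-1-yl in place of 3,4-dichlorophenyl on an amide-type nitrogen. Within the data shown here, no measured pair shows this change, so its size and direction rest on nothing firm. A step no larger than modest is expected, if anything toward a weaker number. This corresponds to an expected step of a 1.5-fold higher number from compound 2 to compound 3 (0.18 log units; within the scatter). Compound 3 is accordingly estimated to give about 2000 nM in this assay, with a plausible range from 500 nM to 8000 nM.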

Compound 3, half-maximal inhibitory concentration: 703 nM
Compound 3: the middle estimate sits 2.8-fold (0.45 log units) above what was measured; the range from low to high includes it.
By their numbers in this assay, from the lowest: compounds 3 and 2 (each within the scatter of the next); then compound 1.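

In this assay, among these compounds, naphthalen-1-yl in place of 3,4-dichlorophenyl on an amide-type nitrogen gives a 1.9-fold lower number from compound 2 to compound 3 (0.27 log units; within the scatter), the first comparison that isolates a single place. At this position, a second six-membered aromatic ring of carbon only can therefore replace the dichlorinated ring, with both chlorine atoms gone, without a step beyond the scatter. No supporting data bear on the reason for this result.

From the compounds shown here alone, this is one pair on one substitution pattern of the shared core, so it remains open whether the same change behaves alike with a different benzyl ether on that core. Also open, going by these compounds, is how this nitrogen responds to unsubstituted phenyl, naphthalen-2-yl, or a saturated ring such as cyclohexyl.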